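The source may hold more compounds than are shown below. What is called first, only, known or untested is meant among the compounds shown, and "the series" means these compounds.

Compound 2 `COc1cc2ncnc(Nc3ccc(F)c(Br)c3)c2cc1OCCCN1CCNCCNCC1` belongs to a small set of anilino-substituted compounds built on one shared core and tested in a functional assay on A-431 cells (Homo sapiens) for antiproliferative activity, read by MTT assay, with a stated time of 72 h (on this read-out higher numbers stand for weaker inhibition and lower numbers for stronger inhibition), where compound 2 gives 1060 nM. Within the data shown here, its only measured companion is compound 1 `COc1cc2ncnc(Nc3ccc(Br)cc3F)c2cc1OCCCN1CCNCCNCC1`, which in this assay gives 561 nM; the sole recorded step, a 1.9-fold higher number from compound 1 to compound 2 (0.28 log units; within the scatter), moves the two halogens around the anilino ring and leaves the two numbers unseparated, so compound 2 stands alongside compound 1 rather than apart from it.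

Compound 3 `COc1cc2ncnc(Nc3cccc(F)c3)c2cc1OCCCN1CCNCCNCC1` is the next question. The change is 3-fluorophenyl in place of 3-bromo-4-fluorophenyl on a nitrogen on an aromatic ring. Among the measured compounds shown here, no measured step removes a bromine; the one step available only rearranges halogens and was within the scatter, so it gives no firm guide. Compound 3 is therefore expected to sit near compound 2 or somewhat weaker, with an estimated step of a 2.4-fold higher number from compound 2 to compound 3 (0.37 log units; beyond the scatter). Compound 3 is estimated at 2500 nM, with a range from 800 nM to 8000 nM.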

Compound 3, half-maximal inhibitory concentration: 7910 nM
The estimate for compound 3 lay 3.2-fold (0.50 log units) below the measured number; low and high end bracket the measured number.
By their numbers in this assay, from the lowest: compounds 1 and 2 (each within the scatter of the next); then compound 3.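

In this assay, among these compounds, the loss of the bromine from the group on a nitrogen on an aromatic ring gives a 7.5-fold higher number from compound 2 to compound 3 (0.87 log units; beyond the scatter) and is the first change here to lie beyond the scatter. Compound 1 carries its halogens differently, and the change to the 3-fluorophenyl group gives a 14-fold higher number from compound 1 to compound 3 (1.15 log units; beyond the scatter) in the same direction, although this step also changes the fluorine's place. Both bromine-bearing compounds therefore give lower numbers than compound 3, but nothing shown here explains this difference.

The compounds shown leave open whether a 3-bromophenyl group, with bromine and no fluorine, would keep the lower numbers. They also leave open how in this assay a 3-chlorophenyl or 3-ethynylphenyl group would compare with the bromine-bearing groups.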